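Two Pyrimidinyl Ureas Measured, a Third Awaiting Its Result

A few compounds are considered here, and "the series" means these few. Any claim that something is new, unique, unknown or untested is made for them only; others in the source may bear on it.

Measured compounds:
compound 1, `COc1ccc(F)cc1Nc1cc(NC(=O)Nc2c(Cl)cccc2Cl)ncn1`, gives 38.1%
compound 2, `COc1cc(NC(=O)Nc2cc(Nc3ccc(C)c(F)c3)ncn2)cc(OC)c1`, gives 30.6%

Both numbers come from a functional assay on NCI-H520 cells (Homo sapiens) for inhibition, read by MTT assay, with a stated time of 48 h, tested at 10 uM; a lower number here means less inhibition, a higher number more inhibition at the concentration tested (going by the name of the read-out). Compound 2 stands lowest of the two values, but its nearest neighbour, compound 1, lies within the usual scatter of it, so the two numbers cannot be told apart by this assay, and the inhibition of compound 2 in this assay can only be called level with that of compound 1. Within the data shown here, no step between compounds differing in one place is available among the measured compounds, so no measured step can guide what follows.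

The next compound, compound 3, is `COc1cc(NC(=O)Nc2cc(Nc3ccc(Br)cc3OC)ncn2)cc(OC)c1`. It differs from compound 2 in one place: 4-bromo-2-methoxyphenyl in place of 3-fluoro-4-methylphenyl on a nitrogen on an aromatic ring. Nothing measured here speaks for or against such an exchange on a nitrogen on an aromatic ring, as both measured compounds carry different groups at more than one position.

Among the measured compounds shown here, with no measured step to lean on, the expected step is none beyond the scatter; the estimated change from compound 2 to compound 3 is a number 2.4 percentage points higher from compound 2 to compound 3 (within the scatter). Compound 3 is therefore expected to give about 33% in this assay, within a range of 15% to 52%.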

Compound 3, a percentage reported as inhibition, at one concentration (the size of the read-out at that concentration, not a potency): 36.1%
Compound 3: the middle estimate sits 3.1 percentage points below what was measured, within the range that was stated.
By their numbers in this assay, from the lowest: compounds 2, 3 and 1 (each within the scatter of the next).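

Among these compounds, the exchange of 3-fluoro-4-methylphenyl for 4-bromo-2-methoxyphenyl on a nitrogen on an aromatic ring gives the first comparison here of compounds differing in one place, and it reads as a number 5.5 percentage points higher from compound 2 to compound 3 (within the scatter) in this assay and so leaves the two compounds level. At this position, then, a group with one hydrogen-bond acceptor and a bromine can stand in place of one with no hydrogen-bond acceptor and a fluorine without a difference this assay can resolve, although this rests on a single pair and cannot be stretched into a rule for the position. Nothing available on these compounds accounts for this result, so it stands as an observation without an explanation.

The compounds shown leave open whether any group on this nitrogen would lift the inhibition beyond the scatter, for instance a phenyl ring carrying a morpholine, a carboxylic acid or a longer alkyl chain. They also leave open how much the other aryl group on the shared core matters, as compound 1 differs from the others in more than one place.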